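The source may report more compounds than this note shows. Statements on the series, on what has been measured and on what is new or still open speak of the compounds shown alone.

Within the data shown here, the three compounds measured so far share one core and differ only in the group on a saturated chain carbon bound to an aromatic carbon and a double-bonded chain carbon. In a physicochemical assay for solubility, in phosphate buffer, measured as kinetic solubility (a higher number here means a more soluble compound, a lower number a less soluble compound), compound 1 `CCC(CC)C(/C=C1\OC(=O)NC1=O)c1ccc(-c2ccc3cccc(F)c3c2)[nH]c1=O` gives 33700 nM, the highest of the three numbers in hand. Compound 2 `CCC(/C=C1\OC(=O)NC1=O)(CC)c1ccc(-c2ccc3cccc(F)c3c2)[nH]c1=O` gives 32600 nM in this assay, a number within the scatter of that of compound 1, so the two cannot be placed in any order. Among the measured compounds shown here, compound 3 `CC(C)C(CC1NC(=O)NC1=O)c1ccc(-c2ccc3cccc(F)c3c2)[nH]c1=O` gives 12300 nM in this assay, and that number lies below the one for compound 1 by more than the scatter.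

Compound 4 `O=C1NC(=O)/C(=C/C(c2ccccc2)c2ccc(-c3ccc4cccc(F)c4c3)[nH]c2=O)O1` has not yet been measured. It differs from compound 1 in one place: phenyl in place of pentan-3-yl on a saturated chain carbon bound to an aromatic carbon and a double-bonded chain carbon. For the measured compounds named here, no step between measured compounds mirrors this change, so there is no direct precedent to lean on. The step of a 1.3-fold lower number from compound 1 to compound 4 (0.13 log units; within the scatter) is expected to be small, either within the scatter or a modest fall. Compound 4 is therefore estimated at 25000 nM, with a range from 8000 nM to 60000 nM.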

Compound 4, solubility: 32800 nM
Compound 4: the middle estimate sits 1.3-fold (0.12 log units) below what was measured; measured number inside the range.
By their numbers in this assay, from the lowest: compound 3; then compounds 2, 4 and 1 (each within the scatter of the next).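

Among these compounds, the step of a 1.0-fold lower number from compound 1 to compound 4 (0.01 log units; within the scatter) is the first one measured at this position, and it is a reading in this assay for a change of group alone, with the rest of compound 1 held fixed. It shows that phenyl in place of pentan-3-yl, on a saturated chain carbon bound to an aromatic carbon and a double-bonded chain carbon, cannot be told apart from the original in this read-out. A group with one six-membered aromatic ring of carbon only and a group with no ring thus give numbers that cannot be placed in any order here.

The compounds shown leave open whether an amine, a carboxylic acid or a longer chain at this position would also read alike in this assay. They also leave open whether phenyl would do the same on the core of compound 3. Nothing given here accounts for the result.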